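Amide-side variation on a shared aminothiazole core

The source may hold more compounds than are shown below. What is called first, only, known or untested is meant among the compounds shown, and "the series" means these compounds.

Measured compounds in an assay on brain for displacement of a labelled ligand from D(3) dopamine receptor (Rattus norvegicus); a lower number here means a stronger inhibitor, a higher number a weaker inhibitor:
Compound 1, `CCCN(CC[C@H]1CC[C@H](NC(=O)/C=C/c2ccc(Cl)cc2)CC1)[C@H]1CCc2nc(N)sc2C1`, gives 2.5 nM.
Compound 2, `CCCN(CC[C@H]1CC[C@H](NC(=O)/C=C/c2ccccc2Cl)CC1)[C@H]1CCc2nc(N)sc2C1`, gives 1.2 nM.
Compound 3, `CCCN(CC[C@H]1CC[C@H](NC(=O)c2ccc(-n3cncn3)cc2)CC1)[C@H]1CCc2nc(N)sc2C1`, gives 2.4 nM.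

Compound 3 stands second highest of the three numbers. Its nearest neighbour is compound 1, the two values being within the scatter, and compound 2 lies at the other end, also within the scatter (a 2.0-fold higher number from compound 2 to compound 3 (0.30 log units; within the scatter)). All three measured compounds share the same core and differ only in the group on the carbonyl carbon of the amide. Exchanging 2-chlorophenyl for 4-chlorophenyl gave a modest step beyond the scatter (a 2.1-fold lower number from compound 1 to compound 2 (0.32 log units; beyond the scatter)), whereas replacing the whole chlorophenylethenyl chain by a triazolylphenyl group left the number unchanged (a 1.0-fold lower number from compound 1 to compound 3 (0.02 log units; within the scatter)).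

Compound 4, `CCCN(CC[C@H]1CC[C@H](NC(=O)c2ccc(-c3noc(C(C)C)n3)cc2)CC1)[C@H]1CCc2nc(N)sc2C1`, differs from compound 3 by 5-isopropyl-1,2,4-oxadiazol-3-yl in place of 1H-1,2,4-triazol-1-yl on an aromatic carbon. Every measured step bears on this region, and even the largest swap there, from compound 1 to compound 3, stayed within the scatter; only the chlorine shift produced a modest step. Exchanging one five-membered ring with three hetero atoms for another on the same phenyl is therefore expected to give a step no larger than the scatter, a 1.2-fold lower number from compound 3 to compound 4 (0.08 log units; within the scatter). Compound 4 is estimated at 2 nM in this assay, with a range from 0.7 nM to 6 nM.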

Compound 4, inhibition constant: 2 nM
Estimate against measurement, compound 4: no gap at the digits printed; the measured number falls inside the stated range.
By their numbers in this assay, from the lowest: compounds 2, 4, 3 and 1 (each within the scatter of the next, the first and the last beyond it).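

In this assay, placing 5-isopropyl-1,2,4-oxadiazol-3-yl where 1H-1,2,4-triazol-1-yl stood gives a small step (a 1.2-fold lower number from compound 3 to compound 4 (0.08 log units; within the scatter)). This aromatic carbon, para to a large group, therefore accepts a substituent of 8 heavy atoms in place of one of 5 with no step beyond the scatter, and the earlier compounds had shown only the triazolyl group here. The two groups share a five-membered aromatic ring with 3 hetero atoms and the same counts of donors and acceptors, but the entering ring carries oxygen and an isopropyl branch, and neither difference moves the number beyond the scatter; no measurement at hand explains this tolerance.

The compounds shown cannot separate the effect of exchanging the ring from that of adding the isopropyl group, as an unsubstituted 1,2,4-oxadiazol-3-yl or a 5-methyl-1,2,4-oxadiazol-3-yl group would begin to do. From the compounds shown here alone, it also remains open whether this tolerance extends to a longer chain such as n-hexyl in place of isopropyl, or to a carboxylic acid or a primary amine on the same aromatic carbon.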